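A few compounds are considered here, and "the series" means these few. Any claim that something is new, unique, unknown or untested is made for them only; others in the source may bear on it.

Compound 1 `Cc1cc(C)cc(S(=O)(=O)n2c(=O)[nH]c3ccc(Cl)cc32)c1`: 39000 nM
Compound 2 `Cc1cc(C)cc(S(=O)(=O)n2c(=O)[nH]c3ccc(Cl)nc32)c1`: > 272000 nM
Compound 3 `Cc1ccc(S(=O)(=O)n2c(=S)[nH]c3ccc(Cl)cc32)cc1C`: 34900 nM

These three compounds were tested in an ADME assay on MT4 cells (Homo sapiens) for cytotoxicity; a higher number here means that more compound is tolerated, a lower number that less compound is tolerated. Compound 1 gives 39000 nM and compound 3 gives 34900 nM, so these two numbers lie within the usual scatter of each other. Compound 2 gives > 272000 nM, which is a limit of the assay and not a number. Among the measured compounds shown here, compound 1 therefore stands level with compound 3, the only other compound with an exact number.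

The next compound to be tested is compound 4 `Cc1cccc(S(=O)(=O)n2c(=O)[nH]c3ccc(Cl)cc32)c1`, which has not yet been measured in this assay. It differs from compound 1 by a single small edit hydrogen in place of methyl on an aromatic carbon, at a place meta to a large group and meta to a methyl group.

For the measured compounds named here, no pair of measured compounds shows this edit on its own, so the data give no direct guide to its size. With so small a change, no shift beyond the scatter is expected, and the estimate stays close to compound 1 at 39000 nM. The expected 1.2-fold higher number from compound 1 to compound 4 (0.06 log units; within the scatter) is therefore small and has no firm direction. For compound 4 the estimated value is 45000 nM, with an expected range from 20000 nM to 120000 nM.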

Compound 4, half-maximal cytotoxic concentration: > 307000 nM
Compound 4 ended at the assay's limit (the forecaster's own chance of this, stated with the estimate: 20%); middle value at least 6.8-fold (0.83 log units) from the limit.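

In this assay, hydrogen in place of methyl on an aromatic carbon, at a place meta to a large group and meta to a methyl group, gives an at least 7.8-fold higher number from compound 1 to compound 4 (0.89 log units; beyond the scatter). Compound 4 gives > 307000 nM, which is a limit of the assay and not a number. Among the compounds shown here, the earlier compounds offered no pair differing in one place, so this is the first change that can be read on its own, and it shows that losing a single carbon atom, with no change in the count of hydrogen-bond donors or acceptors and no net charge, is enough to move the number beyond the scatter at this position.

The compounds shown leave open whether the second methyl group matters in the same way, and whether this step would look alike on a different core. They also leave open what other groups at this same place would do, such as an ethyl group, a methoxy group, an amine or a carboxylic acid, and so whether the size of the group or its kind counts here.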